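The source may hold more compounds than are shown below. What is called first, only, known or untested is meant among the compounds shown, and "the series" means these compounds.

Measured so far in a functional assay on PC-3 cells (Homo sapiens) for antiproliferative activity, read by MTT assay, with a stated time of 72 h (on this read-out lower numbers stand for stronger inhibition and higher numbers for weaker inhibition), are three compounds
- compound 1 `O=C(N/N=C/c1ccc(F)cc1)Nc1ccc(Oc2ccnc3[nH]ccc23)c(F)c1` gives 2330 nM
- compound 2 `O=C(N/N=C/c1ccc(F)cc1)Nc1ccc(Oc2ccnc3[nH]ccc23)cc1` gives 7490 nM
- compound 3 `O=C(N/N=C/c1cccn1CCCN1CCCC1)Nc1ccc(Oc2ccnc3[nH]ccc23)c(F)c1` gives 3580 nM

For the measured compounds named here, of these three numbers, the one for compound 2 is the highest, which here means the weakest inhibition of growth. Compound 4 `CN(C)CCCn1cccc1/C=N/NC(=O)Nc1ccc(Oc2ccnc3[nH]ccc23)cc1` keeps the core of compound 2 and changes one group: 1-(3-(dimethylamino)propyl)-1H-pyrrol-2-yl in place of 4-fluorophenyl on a carbon with a double bond to nitrogen. In words, this is 1-(3-(dimethylamino)propyl)-1H-pyrrol-2-yl in place of 4-fluorophenyl on a carbon with a double bond to nitrogen.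

Going by the values given here, the only step worked out so far, a 3.2-fold higher number from compound 1 to compound 2 (0.51 log units; beyond the scatter), concerns a fluoro on the shared core that compound 2 and compound 4 both lack, so it says little about this swap. A closer guide is the pair of compound 1 at 2330 nM and compound 3 at 3580 nM, two values within the usual scatter of each other. That pair makes a similar swap, although the side chain of compound 3 ends differently from that of compound 4. On this evidence, no change beyond the scatter is expected in this assay. The expected change is a 1.2-fold higher number from compound 2 to compound 4 (0.08 log units; within the scatter) and it rests on a single pair. Compound 4 is estimated at 9000 nM with an expected range from 3500 nM to 22000 nM as its bounds.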

Compound 4, half-maximal inhibitory concentration: 5150 nM
Estimate against measurement, compound 4: 1.7-fold (0.24 log units) above, within the range that was stated.
By their numbers in this assay, from the lowest: compounds 1, 3, 4 and 2 (each within the scatter of the next, the first and the last beyond it).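

On the carbon with a double bond to nitrogen, this assay shows a 1.5-fold lower number from compound 2 to compound 4 (0.16 log units; within the scatter) when 1-(3-(dimethylamino)propyl)-1H-pyrrol-2-yl replaces 4-fluorophenyl, so this swap does not move the number beyond the usual scatter. The change in structure is not small: the group that enters has more heavy atoms than the group that leaves, a five-membered aromatic ring with 1 hetero atom replaces a six-membered aromatic ring of carbon only, and the count of hydrogen-bond acceptors goes from 0 to 2. For this one pair, then, a large difference in the group at this position comes with no clear difference in inhibition of growth, though nothing available explains that result.

Compound 3 and compound 4 differ in more than one place, so the end of the side chain and the fluoro on the core cannot be judged separately from this pair. As far as these compounds go, it also remains open whether a morpholine at the end of the propyl chain, a longer butyl chain, or a pyrrol-2-yl ring with no side chain at all would keep the number in the same range.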